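Exchanging the aromatic end group on the side chain

The source may report more compounds than this note shows. Statements on the series, on what has been measured and on what is new or still open speak of the compounds shown alone.

Compound 3 `COc1cc(OC)c2c(=O)c(OCC(=O)N/N=C/c3ccc(C)cc3)c(-c3cc(OC)c(OC)c(OC)c3)oc2c1` carries the shared core with a side chain ending in a 4-methylphenyl group. In a functional assay on MDA-MB-231 cells (Homo sapiens) for cytotoxicity, read by MTT assay, with a stated time of 38 h (on this read-out higher numbers stand for weaker inhibition and lower numbers for stronger inhibition), compound 3 gives 4570 nM, which places it second highest of the three numbers. Compound 1 `COc1cc(OC)c2c(=O)c(OCC(=O)N/N=C/c3sccc3C)c(-c3cc(OC)c(OC)c(OC)c3)oc2c1` differs only in the 3-methylthiophen-2-yl group on the same carbon; in this assay compound 1 gives 4470 nM, and the step of a 1.0-fold higher number from compound 1 to compound 3 (0.01 log units; within the scatter) lies within the scatter. Compound 2 `COc1cc(OC)c2c(=O)c(OCCCN3CCN(C)CC3)c(-c3cc(OC)c(OC)c(OC)c3)oc2c1` carries a different group on the saturated chain carbon bound to an oxygen on an aromatic ring; in this assay compound 2 gives 30100 nM, and the steps of a 6.7-fold higher number from compound 1 to compound 2 (0.83 log units; beyond the scatter) and a 6.6-fold lower number from compound 2 to compound 3 (0.82 log units; beyond the scatter) show that this exchange matters far more than the exchange of the aromatic group at the chain end.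

Compound 4 `COc1cc(OC)c2c(=O)c(OCC(=O)N/N=C/c3ccccn3)c(-c3cc(OC)c(OC)c(OC)c3)oc2c1` has not been measured. It differs from compound 3 in one place: pyridin-2-yl in place of 4-methylphenyl on a carbon with a double bond to nitrogen. For the measured compounds named here, the only measured step that bears on this change is a 1.0-fold higher number from compound 1 to compound 3 (0.01 log units; within the scatter), where an aromatic group on the same carbon was exchanged without a step beyond the scatter. Going by the values given here, no measured compound here carries a six-membered aromatic ring with 1 hetero atom at that position. Compound 4 is therefore expected to give a number close to that of compound 3, with the step of a 1.0-fold lower number from compound 3 to compound 4 (0.01 log units; within the scatter) expected to stay within the scatter. For compound 4 the estimate in this assay is 4500 nM, with a range from 1800 nM to 11000 nM.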

Compound 4, half-maximal inhibitory concentration: 9890 nM
Estimate against measurement, compound 4: 2.2-fold (0.34 log units) below; measured number inside the range.
By their numbers in this assay, from the lowest: compounds 1 and 3 (each within the scatter of the next); then compound 4; then compound 2.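

In this assay, the group on the carbon with a double bond to nitrogen proves not to be freely exchangeable: a 2.2-fold higher number from compound 3 to compound 4 (0.34 log units; beyond the scatter) and a 2.2-fold higher number from compound 1 to compound 4 (0.34 log units; beyond the scatter) both lie beyond the scatter, whereas the exchange a 1.0-fold higher number from compound 1 to compound 3 (0.01 log units; within the scatter) did not. Pyridin-2-yl, which brings a ring nitrogen and a hydrogen-bond acceptor that 4-methylphenyl lacks, is the only group shown at this place that moves the number, yet a 3.0-fold lower number from compound 2 to compound 4 (0.48 log units; beyond the scatter) shows that this side chain still stays clearly apart from the one ending in the six-membered non-aromatic ring. Nothing measured here explains the step, so the data give its size but not its cause.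

Pyridin-2-yl differs from 4-methylphenyl both in the ring nitrogen and in the missing methyl group, and the compounds shown do not separate these two changes. A plain phenyl group at this carbon would address that question, while pyridin-3-yl or pyridin-4-yl would show whether the place of the ring nitrogen matters to the number.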